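Cytotoxicity notes: from compound 3 to compound 4

The compounds below may be only part of what the source reports. "The series", "measured", "known", "first", "only" and "open" are said of these compounds alone.

- Compound 1 `C=C[C@@](C)(/C=C/c1ccc(OCc2ccccc2)cc1)CCC=C(C)C` gives > 26000 nM as a limit
- Compound 2 `C=C[C@@](C)(/C=C/c1ccc(OS(=O)(=O)c2ccc(C)cc2)cc1)CCC=C(C)C` gives > 26000 nM as a limit
- Compound 3 `C=C[C@@](C)(/C=C/c1ccc(O)cc1)CCC1OC1(C)C` gives > 22500 nM as a limit

In a functional assay on Raji cells (Homo sapiens) for cytotoxicity, with a stated time of 72 h (on this read-out higher numbers stand for an effect only at larger amounts of compound and lower numbers for an effect already at smaller amounts), compound 3 gives > 22500 nM as a limit and not a number. For the measured compounds named here, it is the only compound at the limit of > 22500 nM in this assay, at which 1 of the 3 values shown sits, and the other two sit at the limit of > 26000 nM in this assay, at which 2 of the 3 values shown sit, so that all three values shown are limits and no order among them can be read.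

Compound 4 `C=C[C@@](C)(/C=C/c1ccc(O)cc1)CC/C=C/C(=O)OCC` carries 2-(ethoxycarbonyl)ethenyl in place of 3,3-dimethyloxiran-2-yl on a saturated chain carbon, three bonds along the chain from two double-bonded chain carbons, with the full count being 2-(ethoxycarbonyl)ethenyl in place of 3,3-dimethyloxiran-2-yl on a saturated chain carbon, three bonds along the chain from two double-bonded chain carbons for this change.

Going by the values given here, no measured pair gives a step to compare with this change. The expectation rests on compound 3, whose limit is > 22500 nM in this assay as the nearest reference. The expected change a step that the limit leaves unreadable from compound 3 to compound 4 is none beyond the usual scatter. For compound 4 the estimate is 25000 nM with an expected range of 9000 nM to 60000 nM and a report as a limit is the likelier outcome.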

Compound 4, half-maximal effective concentration: > 26000 nM
Compound 4 gave a limit, no number (the forecaster's own chance of this, stated with the estimate: 75%); middle value at least 1.0-fold (0.01 log units) from the limit.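

In this assay compound 3 gives > 22500 nM, a limit. For the compounds shown here, compound 4 gives > 26000 nM, also a limit, so no step between compound 3 and compound 4 can be read. The compounds shown leave open whether 2-(ethoxycarbonyl)ethenyl in place of 3,3-dimethyloxiran-2-yl alters cytotoxicity at all, and at what concentration any of the four compounds would show an effect.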